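The source may hold more compounds than are shown below. What is called first, only, known or untested is meant among the compounds shown, and "the series" means these compounds.

In a functional assay on SiHa cells (Homo sapiens) for inhibition, read by sulforhodamine B assay (on this read-out higher numbers stand for weaker inhibition of growth and lower numbers for stronger inhibition of growth), compound 1 `Cc1ccc2[nH]c(-c3ccc(-c4ccc(-c5ccccc5)cc4)cc3)nc2c1` gives 35200 nM and compound 2 `Cc1ccc2[nH]c(-c3ccc(-c4ccc(-c5ccc(F)cc5)cc4)cc3)nc2c1` gives 41000 nM. These two numbers lie within the scatter of each other, so compound 2 stands level with compound 1 and the pair sets the only reference range so far.

Compound 3 `Cc1ccc2[nH]c(-c3ccc(-c4ccc(-c5ccc(C(F)(F)F)cc5)cc4)cc3)nc2c1` carries trifluoromethyl in place of fluoro on an aromatic carbon, para to a large group (trifluoromethyl in place of fluoro on an aromatic carbon). Going by the values given here, the only measured step at this place, fluoro in place of hydrogen, is a 1.2-fold higher number from compound 1 to compound 2 (0.07 log units; within the scatter). Among the compounds with values here, no measured compound carries trifluoromethyl, so this one small step is weak guidance and gives no direction. No change beyond the scatter is therefore expected in this assay. The estimated step is a 1.0-fold lower number from compound 2 to compound 3 (0.01 log units; within the scatter). For compound 3 the expected value is 40000 nM, with an estimated range of 22000 nM to 75000 nM.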

Compound 3, concentration for 50% growth inhibition: 33200 nM
The estimate for compound 3 lay 1.2-fold (0.08 log units) above the measured number, and the stated range covers the measured number.
By their numbers in this assay, from the lowest: compounds 3, 1 and 2 (each within the scatter of the next).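

In this assay, trifluoromethyl on this aromatic carbon, para to a large group, gives a 1.2-fold lower number from compound 2 to compound 3 (0.09 log units; within the scatter) and, set against hydrogen at the same place, gives a 1.1-fold lower number from compound 1 to compound 3 (0.03 log units; within the scatter). The earlier pair covered only hydrogen and fluoro, whereas these steps add a larger group with more heavy atoms, and hydrogen, fluoro and trifluoromethyl still stand level at this position. No available evidence bears on why this exchange leaves the number within the scatter.

As far as these compounds go, whether any group at this place can move the number beyond the scatter remains open, for example an amine, a carboxylic acid or a longer alkyl chain. Also open, from the compounds shown here alone, is whether a change elsewhere on the shared core would do so, and whether the level result at this position would then still hold.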